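The source may hold more compounds than are shown below. What is called first, only, known or untested is meant among the compounds shown, and "the series" means these compounds.

In a functional assay on ECa-109 cells for antiproliferative activity against ECa-109 cell line (Homo sapiens), read by MTT assay, with a stated time of 48 h (on this read-out higher numbers stand for weaker inhibition and lower numbers for stronger inhibition), the compounds measured so far give:

- compound 1 `COc1ccc(CN(C(=O)CSc2ccccn2)c2cc(OC)c(OC)c(OC)c2)cc1`: 16000 nM
- compound 2 `COc1ccc(CN(C(=O)CSc2nnnn2C)c2cc(OC)c(OC)c(OC)c2)cc1`: 5540 nM

Compound 2 holds the lower of the two numbers, the stronger inhibition so far. Compound 3 `COc1ccc(CN(C(=O)CSc2nc3ccccc3[nH]2)c2cc(OC)c(OC)c(OC)c2)cc1`, not yet measured, changes the group on the same sulfur: 1H-benzimidazol-2-yl in place of 1-methyl-1H-tetrazol-5-yl on a sulfur. Among the compounds with values here, one measured step bears on this, also a swap of the group on that sulfur: a 2.9-fold lower number from compound 1 to compound 2 (0.46 log units; beyond the scatter). That step is modest, and a single step shows no trend. A step of similar or smaller size is therefore expected in this assay, leaning toward a higher number. The expected change is a 1.4-fold higher number from compound 2 to compound 3 (0.16 log units; within the scatter). For compound 3 the estimate is 8000 nM, within an expected range of 2500 nM to 25000 nM.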

Compound 3, half-maximal inhibitory concentration: 42600 nM
Estimate against measurement, compound 3: 5.3-fold (0.73 log units) below; the whole stated range lies below it.
By their numbers in this assay, from the lowest: compound 2; then compound 1; then compound 3.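

Swapping in 1H-benzimidazol-2-yl gives a 7.7-fold higher number from compound 2 to compound 3 (0.89 log units; beyond the scatter) and a 2.7-fold higher number from compound 1 to compound 3 (0.43 log units; beyond the scatter) on this sulfur, so the group here can also weaken inhibition, and this one is the weakest of the three. It brings a carbon-only six-membered ring and a hydrogen-bond donor together, so the compounds cannot show which of the two goes with the loss. Nothing available explains this loss.

A 1-methyl-1H-benzimidazol-2-yl group, which keeps both rings but lacks that donor, could separate the two, while a simple phenyl group would test whether any nitrogen in the ring matters.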